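This account rests on a few compounds, and the source may have more. Where it says the series, first, only, none or still open, it means among the compounds named here.

Compound 1 `CC(=O)Nc1nc2ccc(-c3cn([C@@H]4CN[C@H](C(=O)Nc5ccc(Cl)cc5Cl)C4)nn3)nc2s1`: 9670 nM
Compound 2 `CC(=O)Nc1nc2ccc(-c3cn([C@@H]4CN[C@H](C(=O)Nc5ccc(Br)cc5)C4)nn3)nc2s1`: 5020 nM
Compound 3 `CC(=O)Nc1nc2ccc(-c3cn([C@@H]4CN[C@H](C(=O)Nc5ccc(F)c(F)c5)C4)nn3)nc2s1`: not yet measured

All values come from a functional assay on K562 cells (Homo sapiens) for inhibition, read by MTT assay, with a stated time of 48 h; a higher number here means a weaker inhibitor, a lower number a stronger inhibitor. Compound 2, at 5020 nM, stands within the scatter of compound 1, so the two are not separated. The change to follow is 3,4-difluorophenyl in place of 4-bromophenyl on an amide-type nitrogen. Within the data shown here, the only measured step at this place is a 1.9-fold lower number from compound 1 to compound 2 (0.28 log units; within the scatter). With that single step as the guide, no change beyond the scatter is expected in this assay. The estimate for compound 3 is 6500 nM, with an expected range of 2500 nM to 17000 nM. This estimate means a 1.3-fold higher number from compound 2 to compound 3 (0.11 log units; within the scatter).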

Compound 3, half-maximal inhibitory concentration: 63000 nM
For compound 3 the middle estimate is 9.7-fold (0.99 log units) below the measured one, outside the stated range (above it).
By their numbers in this assay, from the lowest: compounds 2 and 1 (each within the scatter of the next); then compound 3.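

In this assay the 3,4-difluorophenyl group gives a 13-fold higher number from compound 2 to compound 3 (1.10 log units; beyond the scatter) and a 6.5-fold higher number from compound 1 to compound 3 (0.81 log units; beyond the scatter) so the group on the amide-type nitrogen can move the number beyond the scatter, which the earlier pair did not show. The two halogen patterns of compound 1 and compound 2 stay together, and compound 3 stands apart from both. Nothing available explains this separation.

Left open is whether an unsubstituted phenyl or a 4-fluorophenyl on this nitrogen would read like compound 2 or like compound 3. Also open, on these data alone, is how a pyridyl or cyclohexyl group would read here.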